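From Acetoxyphenyl to Trifluoromethylphenyl at an Assay Limit

A few compounds are considered here, and "the series" means these few. Any claim that something is new, unique, unknown or untested is made for them only; others in the source may bear on it.

Of the compounds shown here, two built on a shared core have been tested so far. In an ADME assay on HEK-293T cells (Homo sapiens) for cytotoxicity, read by MTT assay, with a stated time of 3 days (on this read-out higher numbers stand for lower toxicity in this test and lower numbers for higher toxicity in this test), compound 1 (`CC(C)(C)N(CCC(=O)c1ccccc1)C(=O)COC(=O)c1ccc([N+](=O)[O-])o1`) is recorded as "not active" (no number reported) and carries no number. Compound 2 (`CC(=O)Oc1ccccc1CN(C(=O)COC(=O)c1ccc([N+](=O)[O-])o1)C(C)(C)C`) gives > 100000 nM in this assay and this is a limit of the assay, not a number. Compound 2 therefore has no exact position on the scale, and the comparison that follows starts from a limit.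

Compound 3 (`CC(C)(C)N(Cc1cccc(C(F)(F)F)c1)C(=O)COC(=O)c1ccc([N+](=O)[O-])o1`) has yet to be measured. It carries 3-(trifluoromethyl)phenyl in place of 2-acetoxyphenyl on a saturated chain carbon bound to an amide-type nitrogen while the rest of the molecule stays the same. Among the measured compounds shown here, no measured pair shows what such a swap does, so the data offer no step to copy. With compound 2 at > 100000 nM as a limit, the expectation is no change beyond the usual scatter in this assay and no clear direction. The expected step is a number no higher from compound 2 to compound 3 (the limit leaves the size open) in this estimate. For compound 3 the estimated value is 100000 nM with an expected range of 30000 nM to 200000 nM in this assay.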

Compound 3, half-maximal cytotoxic concentration: 68000 nM
Compound 3: the middle estimate sits 1.5-fold (0.17 log units) above what was measured; the measured number falls inside the stated range.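

Among the compounds shown here, compound 3 gives the first exact number in this assay, 68000 nM, so a compound with this shared core can produce a reading inside the range of the test when a substituted phenyl group sits on a saturated chain carbon bound to an amide-type nitrogen. Replacing 2-acetoxyphenyl with 3-(trifluoromethyl)phenyl at that place gives an at least 1.4-fold lower number from compound 2 to compound 3 (0.16 log units; that floor lies within the scatter), so the smallest step the data allow is not enough to show a real drop. The true size of the step stays open because compound 2 is held at a limit of the assay and not a number: the limit of > 100000 nM in this assay, at which 1 of the 3 values shown sits.

The two groups differ both in what they carry and in where they carry it, so the effect of each cannot be separated without a comparison such as a plain phenyl, 2-(trifluoromethyl)phenyl or 3-acetoxyphenyl at this place. From the compounds shown here alone, it also remains open how the reading would respond to a group of a different kind here, such as a carboxylic acid or an amine.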